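This account rests on a few compounds, and the source may have more. Where it says the series, first, only, none or still open, it means among the compounds named here.

Compound 2 `O=C(Nc1cccc(-n2cc(-c3ccncc3)c(-c3ccc(Cl)c(O)c3)n2)c1)Nc1ccc(Cl)c(Cl)c1` is the reference for this step. In a functional assay on SF-268 cells (Homo sapiens) for inhibition, read by sulforhodamine B assay, with a stated time of 48 h (a higher number here means that more compound is tolerated, a lower number that less compound is tolerated), compound 2 reaches only a limit of the assay, > 32500 nM. Its two neighbours are compound 1 `COc1cc(-c2nn(-c3cccc(NC(=O)Nc4ccc(Cl)c(Cl)c4)c3)cc2-c2ccncc2)ccc1Cl`, which carries methyl in place of hydrogen on an oxygen on an aromatic ring, and compound 3 `COc1cc(-c2nn(-c3cccc(NC(=O)c4ccccc4)c3)cc2-c2ccncc2)ccc1Cl`, which carries phenyl in place of (3,4-dichlorophenyl)amino on a carbonyl carbon. In this assay compound 1 also stops at a limit, > 50000 nM. In this assay compound 3 gives a limit as well, > 100000 nM. The step from compound 1 to compound 2 is therefore a step that the two limits leave unreadable from compound 1 to compound 2, and the step from compound 1 to compound 3 is a step that the two limits leave unreadable from compound 1 to compound 3; all three values shown are limits, (the limit of > 100000 nM in this assay, at which 1 of the 3 values shown sits), the limit of > 32500 nM in this assay, at which 1 of the 3 values shown sits, and (the limit of > 50000 nM in this assay, at which 1 of the 3 values shown sits), so no readable step exists in the set.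

Compound 4 `O=C(Nc1cccc(-n2cc(-c3ccncc3)c(-c3ccc(Cl)c(O)c3)n2)c1)Nc1ccc(Cl)c(C(F)(F)F)c1` differs from compound 2 by trifluoromethyl in place of chloro on an aromatic carbon. Among the compounds with values here, no measured step bears on this change, and every measured compound sits at a limit, so compound 4 is expected to remain at or near a limit, with an expected step from compound 2 to compound 4 of a step that the limit leaves unreadable from compound 2 to compound 4. The estimate for compound 4 in this assay is 50000 nM, within 15000 nM to 150000 nM.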

Compound 4, concentration lethal to 50% of the cells: > 32500 nM
Compound 4 was reported as a limit; the forecaster's own chance of this, stated with the estimate: 75%; the middle value lies beyond the limit too.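

In this assay, compound 4 stops at a limit, > 32500 nM, and compound 2 is a limit as well, so no step can be read between them. The compounds shown leave open whether trifluoromethyl in place of chloro changes the read-out at all, as none of the four gives a readable number.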